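Replacing Chloro with a Much Larger Sulfamoyl Group

This account rests on a few compounds, and the source may have more. Where it says the series, first, only, none or still open, it means among the compounds named here.

For the measured compounds named here, in a functional assay on MIA PaCa-2 cells (Homo sapiens) for inhibition, read by MTT assay (on this read-out lower numbers stand for stronger inhibition and higher numbers for weaker inhibition), compound 2 `CN(C)C(=O)c1cc2cnc(Nc3ccc(Cl)cc3)nc2n1C1CCCC1` gives 13000 nM, the lower of the two numbers so far, while compound 1 `CN(C)C(=O)c1cc2cnc(Nc3ccccc3)nc2n1C1CCCC1` gives 54900 nM. Compound 3 `Cc1cc(C)nc(NS(=O)(=O)c2ccc(Nc3ncc4cc(C(=O)N(C)C)n(C5CCCC5)c4n3)cc2)n1` carries (4,6-dimethylpyrimidin-2-yl)sulfamoyl in place of chloro on an aromatic carbon. Going by the values given here, only one measured step concerns this same place, the modest 4.2-fold lower number from compound 1 to compound 2 (0.63 log units; beyond the scatter), where chloro replaced hydrogen. The incoming group is far larger than chloro, so that single step is only a loose guide. The expected change in this assay is another modest one toward a lower number, a 2.2-fold lower number from compound 2 to compound 3 (0.34 log units; beyond the scatter), although the direction is uncertain. Compound 3 is estimated at 6000 nM, within a range of 1500 nM to 25000 nM.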

Compound 3, half-maximal inhibitory concentration: 8250 nM
Beside the measured number, compound 3's estimate is 1.4-fold (0.14 log units) below it; low and high end bracket the measured number.
By their numbers in this assay, from the lowest: compounds 3 and 2 (each within the scatter of the next); then compound 1.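

In this assay, a far larger group at this place reads the same as chloro, with a 1.6-fold lower number from compound 2 to compound 3 (0.20 log units; within the scatter), so the extra size brings no measurable change. Set against hydrogen, the large group still gives a 6.7-fold lower number from compound 1 to compound 3 (0.82 log units; beyond the scatter), so both substituents tried here keep a lower number than the unsubstituted compound. Nothing measured here gives a reason for this result. Going by these compounds, it remains open whether an amine or a carboxylic acid at this carbon would read the same. Also open, on these data alone, is whether a plain sulfamoyl group, without the dimethylpyrimidine ring, would hold the number.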